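A few compounds are considered here, and "the series" means these few. Any claim that something is new, unique, unknown or untested is made for them only; others in the source may bear on it.

Measured compounds:

Compound 1 `C=C1C[C@]23C[C@@]1(O)CC[C@H]2c1ccc(OS(=O)(=O)c2ccc(C)cc2)c(C)c1[C@@H]3Cn1cc(-c2ccc(C)cc2)nn1`: in a functional assay on MCF7 cells (Homo sapiens) for cytotoxicity, read by MTT assay, with a stated time of 4 days (on this read-out lower numbers stand for stronger inhibition and higher numbers for weaker inhibition), compound 1 gives > 20000 nM, which is a limit of the assay and not a number.
Compound 2 `C=C1C[C@]23C[C@@]1(O)CC[C@H]2c1ccc(OS(=O)(=O)c2ccc(C)cc2)c(C)c1[C@@H]3Cn1cc(-c2ccc(F)cc2)nn1`: in this assay compound 2 gives > 20000 nM, again a limit of the assay rather than a number.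
Compound 3 `C=C1C(=O)[C@]23C[C@@]1(O)CC[C@H]2c1ccc(OS(=O)(=O)c2ccc(C)cc2)c(C)c1[C@@H]3Cn1cc(-c2ccc(F)cc2)nn1`: in this assay compound 3 gives 330 nM.

Compound 1 and compound 2 share a core and differ only in one place, (methyl in place of fluoro on an aromatic carbon). The step between them, a step that the two limits leave unreadable from compound 2 to compound 1, cannot be sized, because both values sit at the limit of > 20000 nM in this assay, at which 2 of the 3 values shown sit. Compound 3 has a different core from compound 2; how the two cores differ is not broken down here. Compound 3 is the only one of the three that yields a number.

Compound 4 `C=C1C(=O)[C@]23C[C@@]1(O)CC[C@H]2c1ccc(OS(=O)(=O)c2ccc(C)cc2)c(C)c1[C@@H]3Cn1cc(-c2ccc(C)cc2)nn1` has not yet been measured. It stands to compound 3 as compound 1 stands to compound 2: the change is methyl in place of fluoro on an aromatic carbon, the same kind of change made before, at a place described in the same words. From compound 2 to compound 1 that change produced no readable step, so there is no measured size to carry over. Compound 3 gives 330 nM, and the expected step to compound 4 in this assay is estimated as a 1.5-fold higher number from compound 3 to compound 4 (0.18 log units; within the scatter), resting on the small size of the group exchanged and the absence of any readable precedent. Compound 4 is therefore expected to come out near 500 nM, somewhere between 150 nM and 3000 nM.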

Compound 4, half-maximal inhibitory concentration: 320 nM
For compound 4 the middle estimate is 1.6-fold (0.19 log units) above the measured one, and the stated range covers the measured number.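

In this assay, putting methyl where fluoro stood, which turns the 4-fluorophenyl group into 4-methylphenyl on the core shared by compound 3 and compound 4, gives a 1.0-fold lower number from compound 3 to compound 4 (0.01 log units; within the scatter), so on this core the two groups cannot be told apart by this read-out. For the compounds shown here, the same exchange on the other core, between compound 2 and compound 1, gives no step that can be read, because neither compound yields a number there: the limit of > 20000 nM in this assay, at which 2 of the 4 values shown sit. Going by these compounds alone, the pair of compounds with a number therefore shows that the exchange is tolerated on one core only, and it does not show that the exchange behaves alike on both, since there is no second step to set beside the first.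

The compounds shown carry only fluoro or methyl at this place on the ring, so how an amine, a carboxylic acid or a longer chain there would read in this assay remains open, and one such group on the core of compound 3 would test whether this place accepts more than a small exchange. Also open, on these data alone, is whether compound 3 and compound 4 would stay this close in a test on any other kind of cell.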